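Replacing dimethylamino with methyl in compound 2

The source may hold more compounds than are shown below. What is called first, only, known or untested is meant among the compounds shown, and "the series" means these compounds.

Measured in a functional assay on MCF7 cells (Homo sapiens) for antiproliferative activity, read by MTT assay, with a stated time of 72 h; on this read-out lower numbers stand for stronger inhibition and higher numbers for weaker inhibition:
compound 1 `CNc1nc(-c2cc(OC)c(OC)c(OC)c2)c(-c2ccc3ccccc3c2)s1`: 21.1 nM
compound 2 `COc1cc(-c2nc(N(C)C)sc2-c2ccc3ccccc3c2)cc(OC)c1OC`: 2390 nM
compound 3 `COc1ccc(-c2sc(N(C)C)nc2-c2cc(OC)c(OC)c(OC)c2)cc1`: 8360 nM

Among these three, compound 2 has the second highest number, with compound 1 lower and compound 3 higher. The next analogue, compound 4 `COc1cc(-c2nc(C)sc2-c2ccc3ccccc3c2)cc(OC)c1OC`, has not yet been measured in this assay. It differs from compound 2 as follows: methyl in place of dimethylamino on an aromatic carbon.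

Within the data shown here, two measured steps bear on this change. The closer one alters the same amino group and is large: a 110-fold higher number from compound 1 to compound 2 (2.05 log units; beyond the scatter). It shows that this assay can respond strongly to a small change in that group. The other step is modest and concerns the naphthalen-2-yl group instead: a 3.5-fold higher number from compound 2 to compound 3 (0.54 log units; beyond the scatter). Among the measured compounds shown here, no measured compound carries methyl on this aromatic carbon, so neither step fixes the outcome, and the range must stay wide. A modest step toward a lower number is expected: a 3.0-fold lower number from compound 2 to compound 4 (0.48 log units; beyond the scatter). For compound 4 the estimated value is 800 nM, with an expected range from 100 nM to 5000 nM.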

Compound 4, half-maximal inhibitory concentration: 33.4 nM
Beside the measured number, compound 4's estimate is 24-fold (1.38 log units) above it; the whole stated range lies above it.
By their numbers in this assay, from the lowest: compounds 1 and 4 (each within the scatter of the next); then compound 2; then compound 3.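

In this assay the change from dimethylamino to methyl on this aromatic carbon gives a 72-fold lower number from compound 2 to compound 4 (1.85 log units; beyond the scatter) and so the weak number of compound 2 goes with dimethylamino at this place and not with the shared core. Methyl and methylamino stand level here, with a 1.6-fold higher number from compound 1 to compound 4 (0.20 log units; within the scatter) in this assay and so a nitrogen on this carbon is not required for a low number. Nothing shown here accounts for why dimethylamino stands apart from the other two groups.

On these data alone, it remains open how ethyl, an unsubstituted amine or a longer chain would fare on this carbon. Also open, as far as these compounds go, is how methyl here would behave with 4-methoxyphenyl in place of naphthalen-2-yl, as that group appears only alongside dimethylamino.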